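Working notes: from compound 3 to compound 4

This account rests on a few compounds, and the source may have more. Where it says the series, first, only, none or still open, it means among the compounds named here.

Measured in an ADME assay on Huh-7 cells (Homo sapiens) for cytotoxicity, read by a luciferase reporter and WST assay, with a stated time of 3 days; on this read-out higher numbers stand for lower toxicity in this test and lower numbers for higher toxicity in this test:
- compound 1 `O=C(Nc1ccccc1)c1c(NO)cc(-c2ccccc2)oc1=O`: 11600 nM
- compound 2 `O=C(Nc1ccc(F)cc1)c1c(NO)cc(-c2ccccc2)oc1=O`: > 20000 nM (a limit)
- compound 3 `Cc1cccc(NC(=O)c2c(NO)cc(-c3ccccc3)oc2=O)c1`: > 20000 nM (a limit)

Compound 3 gives only a limit, > 20000 nM, and no number is known for it. The series offers little resolution here: the limit of > 20000 nM in this assay, at which 2 of the 3 values shown sit.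

The unmeasured compound 4 `CCNC(=O)c1c(NO)cc(-c2ccccc2)oc1=O` carries ethyl in place of 3-methylphenyl on an amide-type nitrogen.

Going by the values given here, two measured steps bear on this change, and only loosely: an at least 1.7-fold higher number from compound 1 to compound 2 (0.23 log units; that floor lies within the scatter) and an at least 1.7-fold higher number from compound 1 to compound 3 (0.23 log units; that floor lies within the scatter). Both put a single group on an aromatic carbon, and neither floor goes beyond the scatter. The step that the two limits leave unreadable from compound 2 to compound 3 gives no readable size. Among the compounds with values here, no measured step replaces the whole aromatic group on the amide nitrogen, so the change to compound 4 has no direct precedent.

Within the data shown here, the only number to anchor the lower side is that of compound 1, at 11600 nM. The expected step is a number no higher from compound 3 to compound 4 (the limit leaves the size open), with no change beyond the scatter foreseen in either direction, and a further limit is quite possible. For compound 4 the estimated value in this assay is 20000 nM, with an expected range from 10000 nM to 40000 nM.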

Compound 4, half-maximal cytotoxic concentration: > 20000 nM
Compound 4: no number, only a limit; the forecaster's own chance of this, stated with the estimate: 60%; the middle value lies on the limit itself.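

In this assay, compound 4 gives a limit and not a number, so replacing the aromatic group on the amide-type nitrogen with ethyl, which has no ring, does not bring a measurable value into this test. Compared with the only measured value in the series, ethyl in place of phenyl gives an at least 1.7-fold higher number from compound 1 to compound 4 (0.23 log units; that floor lies within the scatter), so this change cannot be said to separate compound 4 from compound 1. The steps to compound 4 from compound 2 and from compound 3 cannot be read, and the position remains poorly resolved in this test: the limit of > 20000 nM in this assay, at which 3 of the 4 values shown sit.

Still open, as far as these compounds go, is how far the values of compound 2, compound 3 and compound 4 lie past the limit, and so whether these three differ from one another at all in this assay. Also open, from the compounds shown here alone, is whether a different group on the same nitrogen, such as a longer chain, a chain ending in an amine or one ending in a carboxylic acid, would give a readable number and show how this position affects the read-out.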